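Replacing 1,2,3,4-tetrahydronaphthalen-6-yl with 3-ethylphenyl

The compounds below may be only part of what the source reports. "The series", "measured", "known", "first", "only" and "open" are said of these compounds alone.

In a physicochemical assay for solubility, read by spectrophotometry, in phosphate buffer, with a stated time of 18 h, at pH 7.4 (on this read-out higher numbers stand for higher solubility and lower numbers for lower solubility), compound 1 `Cc1nn(-c2ccccc2)c2nc(-c3ccc(C#N)cc3)c(C#N)c(-c3ccccc3O)c12` gives 1700 nM and compound 2 `Cc1nn(-c2ccccc2)c2nc(-c3ccc4c(c3)CCCC4)c(C#N)c(-c3ccccc3O)c12` gives 13000 nM, the higher of the two numbers. Compound 3 `CCc1cccc(-c2nc3c(c(C)nn3-c3ccccc3)c(-c3ccccc3O)c2C#N)c1` keeps the shared core but carries 3-ethylphenyl in place of 1,2,3,4-tetrahydronaphthalen-6-yl on an aromatic carbon. Going by the values given here, the only measured step, a 7.6-fold higher number from compound 1 to compound 2 (0.88 log units; beyond the scatter), removed 4-cyanophenyl, and no measured step swaps one all-carbon group for another, so it is a weak guide. No step beyond the scatter is therefore expected in this assay, with an estimated 1.2-fold lower number from compound 2 to compound 3 (0.07 log units; within the scatter). For compound 3 the expected value is 11000 nM, with an estimated range of 4500 nM to 27000 nM.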

Compound 3, solubility: 11000 nM
Beside the measured number, compound 3's estimate shows no gap at the digits printed; the range from low to high includes it.
By their numbers in this assay, from the lowest: compound 1; then compounds 3 and 2 (each within the scatter of the next).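

In this assay, 3-ethylphenyl in place of 1,2,3,4-tetrahydronaphthalen-6-yl gives a 1.2-fold lower number from compound 2 to compound 3 (0.07 log units; within the scatter), so at this position the six-membered non-aromatic ring can go without a step beyond the scatter. Replacing 4-cyanophenyl with 3-ethylphenyl gives a 6.5-fold higher number from compound 1 to compound 3 (0.81 log units; beyond the scatter), so a second all-carbon group also stands clear of 4-cyanophenyl, and neither compound goes against this. No evidence is available on the cause of either step. Still open, on these data alone, is how a phenyl group carrying an amine, a carboxylic acid or a longer chain than ethyl would read here.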